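The compounds below may be only part of what the source reports. "The series", "measured", "known", "first", "only" and "open" are said of these compounds alone.

Going by the values given here, in an assay on isolated protein for binding affinity to adenosine receptor A1 (Homo sapiens) (a lower number here means a stronger inhibitor, a higher number a weaker inhibitor), compound 1 `CC1C(=O)c2nc(CCCCN3N=C(Cl)CCC3=O)[nH]c2N(C)C1=O` gives 370 nM, the lowest of the two numbers known so far. Compound 2 `CC1C(=O)c2nc(CCCN3N=C(c4ccccc4)CCC3=O)[nH]c2N(C)C1=O`, which also bears a phenyl, gives 10800 nM in this assay, a weaker result. Among the compounds with values here, compound 3 `CC1C(=O)c2nc(CCCCN3N=C(c4ccccc4)CCC3=O)[nH]c2N(C)C1=O` differs from compound 1 by phenyl in place of chloro on a carbon with a double bond to nitrogen; no measured pair shows this change on its own. The step of a 5.4-fold higher number from compound 1 to compound 3 (0.73 log units; beyond the scatter) is expected to weaken binding beyond the scatter, because compound 2 with its phenyl gives 10800 nM in this assay. For compound 3 the estimate is 2000 nM, within a range from 500 nM to 8000 nM.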

Compound 3, inhibition constant: 2120 nM
Beside the measured number, compound 3's estimate is 1.1-fold (0.03 log units) below it; low and high end bracket the measured number.
By their numbers in this assay, from the lowest: compound 1; then compound 3; then compound 2.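

In this assay, the change of phenyl in place of chloro on a carbon with a double bond to nitrogen can now be read on its own, with the rest of the molecule unchanged: it gives a 5.7-fold higher number from compound 1 to compound 3 (0.76 log units; beyond the scatter). The step is modest, so this position accepts a six-membered aromatic ring, and compound 3 still gives a measurable 2120 nM. Nothing shown here explains the loss. Still open, on these data alone, is whether a methyl, a methoxy or an amine on this carbon would give a number closer to that of compound 1 or compound 3.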